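Replacing isopropoxy with carbamoyl in compound 2

This account rests on a few compounds, and the source may have more. Where it says the series, first, only, none or still open, it means among the compounds named here.

In a functional assay on HeLa cells (Homo sapiens) for antiproliferative activity, read by CCK-8 assay, with a stated time of 72 h (a lower number here means a stronger inhibitor, a higher number a weaker inhibitor), compound 1 (`COc1ccc(-c2cncnc2-c2cc(OC)c(OC)c(OC)c2)cc1F`) gives 500 nM and compound 2 (`COc1cc(-c2ncncc2-c2ccc(OC(C)C)cc2)cc(OC)c1OC`) gives 8360 nM as the higher of the two numbers, a gap well beyond the scatter. Compound 2 is therefore the weaker inhibitor of the pair. Compound 3 (`COc1cc(-c2ncncc2-c2ccc(C(N)=O)cc2)cc(OC)c1OC`) keeps the rest of compound 2 but carries carbamoyl in place of isopropoxy on an aromatic carbon, para to a large group (carbamoyl in place of isopropoxy on an aromatic carbon). Among the compounds with values here, no measured pair differs in one place only, so the data give no direct guide to this change. The expected step of a 1.2-fold higher number from compound 2 to compound 3 (0.08 log units; within the scatter) in this assay is estimated to stay within the scatter, with compound 2 at 8360 nM as the only anchor, and the uncertainty is wide. Compound 3 is estimated at 10000 nM in this assay, with an expected range from 2500 nM to 40000 nM for repeated measurements.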

Compound 3, half-maximal inhibitory concentration: > 100000 nM
Compound 3: no number, only a limit; the forecaster's own chance of this, stated with the estimate: 25%; at least 10-fold (1.00 log units) between middle value and limit.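

In this assay compound 3 gives > 100000 nM, which is a limit of the assay and not a number. Within the data shown here, this is the first change at a single place, and it shows that the group on this aromatic carbon, para to a large group, can decide activity: carbamoyl in place of isopropoxy gives an at least 11-fold higher number from compound 2 to compound 3 (1.07 log units; beyond the scatter), and the wider exchange of the whole aryl group gives an at least 200-fold higher number from compound 1 to compound 3 (2.30 log units; beyond the scatter). Both steps rest on a single value at a limit: the limit of > 100000 nM in this assay, at which 1 of the 3 values shown sits.

What the compounds shown leave open is whether a carboxylic acid, an aminomethyl group or a longer alkoxy chain at this place would behave more like carbamoyl or like isopropoxy. Also open, as far as these compounds go, is what share of the wider step belongs to the fluoro group of compound 1.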